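The compounds below may be only part of what the source reports. "The series", "measured", "known", "first", "only" and "open" are said of these compounds alone.

Measured in a functional assay on HL-60 cells (Homo sapiens) for cytotoxicity, read by WST assay, with a stated time of 48 h; on this read-out higher numbers stand for an effect only at larger amounts of compound and lower numbers for an effect already at smaller amounts:
Compound 1 `CCCCOc1ccccc1C[C@H]1C(=O)OC[C@@H]1Cc1ccccc1`: 20000 nM
Compound 2 `Cc1ccccc1C[C@H]1C(=O)OC[C@@H]1Cc1ccccc1`: 57000 nM

Of these two compounds, compound 2 stands highest at 57000 nM, so its cytotoxic effect appears only at the larger amounts. Among the compounds with values here, its only neighbour on the scale is compound 1, at 20000 nM.

The next compound, compound 3 `O=C1OC[C@H](Cc2ccccc2)[C@H]1Cc1ccccc1Cl`, keeps the shared core and carries chloro in place of methyl on an aromatic carbon. Within the data shown here, no measured step covers this exchange directly. The only one that bears on it is a 2.9-fold higher number from compound 1 to compound 2 (0.45 log units; beyond the scatter), a modest change that lies beyond the scatter and comes from methyl in place of butoxy on an aromatic carbon. Even that exchange of a whole butoxy group moved the number only modestly, so swapping methyl for chloro is expected to produce no step beyond the scatter in this assay, and no clear direction is expected. The estimated step is small: a 1.1-fold lower number from compound 2 to compound 3 (0.06 log units; within the scatter). For compound 3 the expected value is 50000 nM, with an estimated range from 22000 nM to 110000 nM.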

Compound 3, half-maximal effective concentration: 37000 nM
For compound 3 the middle estimate is 1.4-fold (0.13 log units) above the measured one; the measured number falls inside the stated range.
By their numbers in this assay, from the lowest: compounds 1, 3 and 2 (each within the scatter of the next, the first and the last beyond it).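

In this assay, chloro in place of methyl on this aromatic carbon gives a 1.5-fold lower number from compound 2 to compound 3 (0.19 log units; within the scatter), so exchanging one heavy atom for another at this place, on the ring and ortho to a large group, stays inside the usual scatter. Chloro in place of butoxy gives a 1.9-fold higher number from compound 1 to compound 3 (0.27 log units; within the scatter), which is also within the scatter, and compound 3 therefore cannot be told apart from either neighbour, even though the earlier step of a 2.9-fold higher number from compound 1 to compound 2 (0.45 log units; beyond the scatter) lies beyond it. Nothing given here accounts for these numbers or explains why compound 3 falls among them.

Three groups at one place on one core leave open whether the number at this aromatic carbon can move much further in either direction, for instance with a longer chain such as hexyloxy, an amine or a carboxylic acid. Going by these compounds, it also remains open whether chloro or butoxy would give similar numbers at other carbons of this ring, or on the other phenyl ring of the shared core.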